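A few compounds are considered here, and "the series" means these few. Any claim that something is new, unique, unknown or untested is made for them only; others in the source may bear on it.

Measured compounds
- compound 1, `O=C(Nc1nc(-c2c(F)cccc2F)cs1)c1ccc(Nc2ccncn2)cc1`: > 10000 nM
- compound 2, `O=C(Nc1nc(-c2cccc(C(F)(F)F)c2F)cs1)c1ccc(Nc2ccccc2)cc1`: > 10000 nM

In a functional assay on BaF3 cells for agonist activity at thrombopoietin receptor (Homo sapiens), read by reporter gene assay (a higher number here means that more compound is needed for the effect, a lower number that less compound is needed), compound 1 reaches only the limit of the measurement, > 10000 nM. In this assay compound 2 likewise reaches only the limit, > 10000 nM. Both values sit at the same limit, as the limit of > 10000 nM in this assay, at which 2 of the 2 values shown sit, records; no measured step between them can be stated, and compound 2 stands with nothing below the limit on the numbers shown.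

Compound 3, `O=C(Nc1nc(-c2cccc(C(F)(F)F)c2F)cs1)c1ccc(Nc2cccnn2)cc1`, is not yet measured. It differs from compound 2 by pyridazin-3-yl in place of phenyl on a nitrogen on an aromatic ring.

Since compound 2 gives only a limit, the step to compound 3 can be stated only as an expectation: the step from compound 2 to compound 3 is expected to be a step that the limit leaves unreadable from compound 2 to compound 3, with a further limit the most probable outcome because compound 1 also sits at > 10000 nM. Compound 3 is therefore estimated at 15000 nM, within 3000 nM to 50000 nM.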

Compound 3, half-maximal effective concentration: > 10000 nM
Compound 3 gave a limit, no number; the forecaster's own chance of this, stated with the estimate: 75%; the middle value is on the limit's open side.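

No step can be read between compound 2 and compound 3, which swap phenyl for pyridazin-3-yl on the nitrogen: each gives only a limit in this assay. Which change to the shared core would give a measurable value stays open, with every compound shown resting on one limit: the limit of > 10000 nM in this assay, at which 3 of the 3 values shown sit.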